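A few compounds are considered here, and "the series" means these few. Any claim that something is new, unique, unknown or untested is made for them only; others in the source may bear on it.

Three compounds have so far been measured in a functional assay on KB cells (Homo sapiens) for inhibition, read by MTT assay, with a stated time of 24 h, tested at 10 uM; on this read-out higher numbers stand for more inhibition of growth at the one concentration tested and lower numbers for less inhibition of growth:

Compound 1, `CS(=O)(=O)c1ccc(-c2cnc3[nH]cc(-c4nnc(-c5ccc(F)cc5)o4)c(=O)c3c2)cc1`, gives 7.58%.
Compound 2, `CS(=O)(=O)c1ccc(-c2cnc3[nH]cc(-c4nnc(-c5ccc(Cl)cc5)o4)c(=O)c3c2)cc1`, gives 9.3%.
Compound 3, `Cc1ccc(-c2nnc(-c3c[nH]c4ncc(-c5ccc(S(C)(=O)=O)cc5)cc4c3=O)o2)cc1`, gives 3.19%.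

Compound 3 holds the lowest of the three numbers, but the gaps to its neighbours are small: a number 4.4 percentage points lower from compound 1 to compound 3 (within the scatter) and a number 6.1 percentage points lower from compound 2 to compound 3 (within the scatter), so the three compounds are not told apart by these values. The same holds for a number 1.7 percentage points higher from compound 1 to compound 2 (within the scatter).

Compound 4, `Cc1cccc(-c2nnc(-c3c[nH]c4ncc(-c5ccc(S(C)(=O)=O)cc5)cc4c3=O)o2)c1`, is the next candidate. It differs from compound 3 by 3-methylphenyl in place of 4-methylphenyl on an aromatic carbon. The measured steps all swapped one substituent for another on that phenyl ring, fluoro, chloro or methyl, and every one of them stayed within the scatter. Within the data shown here, none of them moved a group to a different position on the ring, so there is no direct precedent for this change. With all known steps flat, no step beyond the scatter is expected here either, and compound 4 is estimated at 5%, between -4% and 14%, a change of a number 1.8 percentage points higher from compound 3 to compound 4 (within the scatter).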

Compound 4, percent growth inhibition at one concentration: 7.5%
For compound 4 the middle estimate is 2.5 percentage points below the measured one; the measured number falls inside the stated range.
By their numbers in this assay, from the lowest: compounds 3, 4, 1 and 2 (each within the scatter of the next).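

Moving the methyl group on this phenyl ring is the first change of position in the set, and it gives a number 4.3 percentage points higher from compound 3 to compound 4 (within the scatter) in this assay. On the aromatic carbon of the five-membered ring, 3-methylphenyl and 4-methylphenyl are therefore not told apart by this read-out. 3-Methylphenyl is also not told apart from 4-chlorophenyl, with a number 1.8 percentage points lower from compound 2 to compound 4 (within the scatter), or from 4-fluorophenyl, with a number 0.1 percentage points lower from compound 1 to compound 4 (within the scatter), so both swapping the substituent and shifting the methyl have left the number flat across these four compounds.

No information is available that bears on why the number stays flat. From the compounds shown here alone, it remains open whether a different group on this phenyl ring, such as an amine or a carboxylic acid, would give a step beyond the scatter.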